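One Swap, From 4-fluorobenzyl to 3-chlorobenzyl

The compounds below may be only part of what the source reports. "The series", "measured", "known", "first", "only" and "open" are said of these compounds alone.

In a functional assay on MDA-MB-231 cells (Homo sapiens) for cytotoxicity, read by MTT assay, with a stated time of 24 h (on this read-out higher numbers stand for weaker inhibition and lower numbers for stronger inhibition), compound 3 `Cc1ccc(/C=C2\CN(C(=S)SCc3cn(Cc4ccc(F)cc4)nn3)C/C(=C\c3ccc(C)cc3)C2=O)cc1` gives 45600 nM as its measured concentration. Compound 2 `Cc1ccc(/C=C2\CN(Cc3cn(Cc4ccc(F)cc4)nn3)C/C(=C\c3ccc(C)cc3)C2=O)cc1` gives 26800 nM and lies within the usual scatter of compound 3, so these two numbers cannot be told apart. Compound 1 `O=C1/C(=C/c2ccccc2F)CN(Cc2cn(Cc3cccc(Cl)c3)nn2)C/C1=C\c1ccccc1F` gives 12000 nM and lies below compound 3 by more than the scatter, which means stronger inhibition.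

Compound 4 `Cc1ccc(/C=C2\CN(C(=S)SCc3cn(Cc4cccc(Cl)c4)nn3)C/C(=C\c3ccc(C)cc3)C2=O)cc1` differs from compound 3 in one place only, and the count of that difference reads 3-chlorophenyl in place of 4-fluorophenyl on a saturated chain carbon bound to an aromatic nitrogen with 3-chlorophenyl in place of 4-fluorophenyl on a saturated chain carbon bound to an aromatic nitrogen. Cut one bond further out, the same difference reads 4-fluorobenzyl to 3-chlorobenzyl.

Among the compounds with values here, no two measured compounds differ in one place alone, so the data hold no direct measure of this swap. The expectation therefore starts from compound 3 at 45600 nM and assumes no shift beyond the scatter in this assay for this change. The expected step is a 1.3-fold lower number from compound 3 to compound 4 (0.10 log units; within the scatter) and it is estimated to stay within the scatter. For compound 4 the estimated value is 36000 nM with an expected range from 15000 nM to 85000 nM in this measurement.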

Compound 4, half-maximal inhibitory concentration: 83000 nM
Estimate against measurement, compound 4: 2.3-fold (0.36 log units) below; the range from low to high includes it.
By their numbers in this assay, from the lowest: compound 1; then compounds 2, 3 and 4 (each within the scatter of the next, the first and the last beyond it).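

In this assay, within the data shown here, replacing 4-fluorobenzyl with 3-chlorobenzyl gives a 1.8-fold higher number from compound 3 to compound 4 (0.26 log units; within the scatter), which is the first direct reading of any change at this position, on a saturated chain carbon bound to an aromatic nitrogen. With everything else in the molecule held the same, compound 3 and compound 4 cannot be told apart, so moving from a fluorine on the phenyl ring to a chlorine at a different ring position produces no shift that this measurement can distinguish from ordinary repeat-to-repeat variation. No measured information is available to explain the result or to assign any property to either group.

This single pair cannot show whether the same swap would also leave the number unresolved on a different version of the molecule, such as the one in compound 2, where no partner differing in this one place is shown. It also leaves open whether a more different group at this position, such as a benzyl carrying an amine or a carboxylic acid, or a phenyl ring on a longer chain, would move the number beyond the scatter in either direction.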